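Swapping a hexyloxy for a benzyloxy on the shared core

This account rests on a few compounds, and the source may have more. Where it says the series, first, only, none or still open, it means among the compounds named here.

Measured compounds:
- Compound 1, `CC(C(=O)NCc1ccc(C(F)(F)Cl)nc1N1CCN(c2ccccc2)CC1)c1ccc(NS(C)(=O)=O)c(F)c1`, gives 0.8 nM in an assay on CHO cells for antagonist activity at transient receptor potential cation channel subfamily V member 1 (Homo sapiens), read by FLIPR; a higher number here means a weaker inhibitor, a lower number a stronger inhibitor.
- Compound 2, `CCCCCCOc1nc(C(F)(F)Cl)ccc1CNC(=O)C(C)c1ccc(NS(C)(=O)=O)c(F)c1`, gives 0.8 nM in this assay.

Compound 2 stands level with compound 1 on the numbers shown: the step of no change at the digits printed from compound 1 to compound 2 (within the scatter) lies within the scatter, so the two compounds cannot be ranked against each other. That step replaced a ring-bearing group on the core with a plain hexyloxy chain and left the read-out where it was.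

Compound 3, `CC(C(=O)NCc1ccc(C(F)(F)Cl)nc1OCc1ccccc1)c1ccc(NS(C)(=O)=O)c(F)c1`, has not yet been measured. It differs from compound 2 by phenyl in place of pentyl on a saturated chain carbon bound to an oxygen on an aromatic ring. Within the data shown here, of the measured steps, only the one from compound 1 to compound 2 touches this part of the molecule, and it showed no change beyond the scatter when a ring-bearing group gave way to a chain. That suggests this region tolerates quite different groups, though a single step is a thin basis. The step of a 1.5-fold higher number from compound 2 to compound 3 (0.18 log units; within the scatter) is therefore expected to be small, with no clear direction beyond the scatter.

Compound 3 is estimated to give 1.2 nM in this assay, with a range from 0.4 nM to 4 nM.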

Compound 3, inhibition constant: 0.9 nM
Beside the measured number, compound 3's estimate is 1.3-fold (0.12 log units) above it, and the stated range covers the measured number.
By their numbers in this assay, from the lowest: compounds 1, 2 and 3 (each within the scatter of the next).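

In this assay, putting phenyl in place of pentyl on a saturated chain carbon bound to an oxygen on an aromatic ring gives a 1.1-fold higher number from compound 2 to compound 3 (0.05 log units; within the scatter), so the hexyloxy chain and the ring-bearing benzyloxy group cannot be told apart here. The comparison with the first group gives a 1.1-fold higher number from compound 1 to compound 3 (0.05 log units; within the scatter) when benzyloxy stands where 4-phenylpiperazin-1-yl stood, which means that 4-phenylpiperazin-1-yl, hexyloxy and benzyloxy now form a set of three different groups on the shared core with values all within the scatter of one another, and none of the three goes against this level picture. Nothing available offers a reason why such different groups read alike.

The three groups shown are all fairly large and built mostly from carbon, so it remains open whether the same level value would hold with a small methoxy group, a free amine or a carboxylic acid at this place. From the compounds shown here alone, it also remains open whether a chain longer than hexyl, or a benzyl ring carrying a substituent of its own, would still fall within the scatter of these three compounds.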